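The compounds below may be only part of what the source reports. "The series", "measured", "known", "first", "only" and "open" are said of these compounds alone.

Measured so far:
compound 1 `O=C(O)c1ccccc1-c1ccc(CCc2ncc(CC3CCCCCC3)[nH]2)cc1` — in an in vitro functional assay on cells for agonist activity at Bombesin receptor subtype-3 (Homo sapiens), read by luminescence and calcium flux (on this read-out lower numbers stand for an effect already at smaller amounts and higher numbers for an effect only at larger amounts of compound), compound 1 gives 88 nM
compound 2 `N#Cc1ccccc1Cc1cnc(CCc2ccc(-c3ccccc3C(=O)O)cc2)[nH]1` — in this assay compound 2 gives 5480 nM

Among the compounds with values here, compound 2 stands highest of the two numbers; its only neighbour is compound 1, reached through the single measured step, a 62-fold higher number from compound 1 to compound 2 (1.79 log units; beyond the scatter), which goes with 2-cyanophenyl in place of cycloheptyl on a saturated chain carbon bound to an aromatic carbon.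

Compound 3 `O=C(O)c1ccccc1-c1ccc(CCc2ncc(Cc3cccc(F)c3)[nH]2)cc1` differs from compound 2 by 3-fluorophenyl in place of 2-cyanophenyl on a saturated chain carbon bound to an aromatic carbon. The measured step bears on this only in part: it exchanged a saturated ring for an aromatic one and brought in the nitrile, whereas the present change keeps an aromatic ring and removes the nitrile. Within the data shown here, no measured pair separates the two parts of that step. The expectation is therefore a move back toward the number of compound 1 without reaching it, a moderate fall in this assay of a 3.7-fold lower number from compound 2 to compound 3 (0.56 log units; beyond the scatter). Compound 3 is estimated at 1500 nM, within 300 nM to 6000 nM.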

Compound 3, half-maximal effective concentration: 159 nM
Compound 3: middle estimate off by 9.4-fold (0.97 log units), on the high side; the whole stated range lies above it.
By their numbers in this assay, from the lowest: compounds 1 and 3 (each within the scatter of the next); then compound 2.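

On the saturated chain carbon bound to an aromatic carbon, an aromatic ring does not by itself go with the high number of compound 2: in this assay, 3-fluorophenyl in place of 2-cyanophenyl gives a 34-fold lower number from compound 2 to compound 3 (1.54 log units; beyond the scatter) and so recovers nearly all of the earlier loss. The step of a 1.8-fold higher number from compound 1 to compound 3 (0.26 log units; within the scatter) leaves cycloheptyl and 3-fluorophenyl at this place indistinguishable, so among these compounds a saturated ring is not required for a number like that of compound 1. Nothing available on these compounds gives a reason for either step.

The 2-cyanophenyl and 3-fluorophenyl groups differ in both substituent and ring numbering, so the two contributions to the large step remain unseparated. Unsubstituted phenyl, 3-cyanophenyl and 2-fluorophenyl on the same carbon would separate them.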